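A few compounds are considered here, and "the series" means these few. Any claim that something is new, unique, unknown or untested is made for them only; others in the source may bear on it.

Working notes on the series. Compound 1 `COc1ccc(CN2C(=O)/C(=C\c3cc(OC)c(OC)c(OC)c3)c3ccccc32)cc1` carries a 4-methoxybenzyl group; in a functional assay on cells (Cancer cell lines, Homo sapiens) for cytotoxicity, with a stated time of 48 h (on this read-out higher numbers stand for weaker inhibition of growth and lower numbers for stronger inhibition of growth), compound 1 gives 17400 nM. Compound 2 `COc1cc(/C=C2\C(=O)N(C)c3ccc(Cl)cc32)cc(OC)c1OC` differs from compound 1 in more than one place; in this assay compound 2 gives 17400 nM; compound 1 and compound 2 stand level at the digits shown, within the usual scatter, so nothing separates them and neither can be called the more or less active of the two. Compound 3 `COc1cc(/C=C2\C(=O)N(Cc3ccc(Cl)cc3)c3ccccc32)cc(OC)c1OC` is the unmeasured member, still to be tested in this assay. Relative to compound 1 the change is chloro in place of methoxy on an aromatic carbon; read one bond further out, 4-methoxybenzyl becomes 4-chlorobenzyl. Among the measured compounds shown here, no measured pair in the set isolates this change, so the size of the step rests on the structural change alone and on where compound 1 stands. The expectation is a small step, if any, leaning slightly toward stronger growth inhibition but not clearly beyond the scatter: the step is estimated as a 1.2-fold lower number from compound 1 to compound 3 (0.06 log units; within the scatter). Compound 3 is accordingly expected to give about 15000 nM in this assay, within a range of 6000 nM to 40000 nM.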

Compound 3, concentration for total growth inhibition: 12900 nM
For compound 3 the middle estimate is 1.2-fold (0.07 log units) above the measured one, within the range that was stated.
By their numbers in this assay, from the lowest: compounds 3, 1 and 2 (each within the scatter of the next).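

In this assay chloro in place of methoxy, on an aromatic carbon para to a large group, gives a 1.3-fold lower number from compound 1 to compound 3 (0.13 log units; within the scatter) and so turns 4-methoxybenzyl into 4-chlorobenzyl without separating the two compounds. This is the only pair shown that differs in one place, and it gives the first direct reading of this position: the swap of these two substituents leaves nothing that distinguishes compound 1 from compound 3 on this read-out, while compound 2 differs from both in more than one place and says nothing about this position. No measured data bear on why the two substituents read alike here.

From the compounds shown here alone, the reading rests on a single pair and on two substituents, so it remains open whether an amine such as dimethylamino, a carboxylic acid or a longer chain such as butoxy on the same aromatic carbon would stand apart from compound 1 and compound 3 in this assay. Going by these compounds, it is also open whether chloro in place of methoxy would read the same way on a different core or with a different group on the benzyl ring's partner, the trimethoxyphenyl group.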